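Taking trifluoromethyl off compound 1: half-life expectation

The compounds below may be only part of what the source reports. "The series", "measured", "known", "first", "only" and "open" are said of these compounds alone.

In an ADME assay on the whole organism (Rattus norvegicus) for metabolic stability, at a dose of 0.5 mg/kg by the intravenous route (a higher number here means that the compound lasts longer, a lower number that the compound disappears faster), compound 1 (`COc1cc(OCc2csc(-c3ccc(C(F)(F)F)cc3)n2)c2cc(-c3cn4nc(OC)sc4n3)oc2c1`) gives 31 h as its half-life. Compound 2 (`COc1cc(OCc2cccc(-c3ccc(OC)nc3)c2)c2cc(-c3cn4nc(OC)sc4n3)oc2c1`) gives 45 h on the same read-out, so the two values lie within the scatter of each other and neither can be ranked above the other. These two numbers are all that is measured so far.

Compound 3 (`COc1cc(OCc2csc(-c3ccccc3)n2)c2cc(-c3cn4nc(OC)sc4n3)oc2c1`) has not yet been measured. It differs from compound 1 in one place (hydrogen in place of trifluoromethyl on an aromatic carbon): hydrogen in place of trifluoromethyl on an aromatic carbon, para to a large group, so that 4-(trifluoromethyl)phenyl becomes phenyl.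

For the measured compounds named here, no measured pair differs in one place, so the data give no direct size for this step in this assay and the expectation is loose. A small downward move is expected, with no step beyond the scatter. The estimated change is a 1.3-fold lower number from compound 1 to compound 3 (0.11 log units; within the scatter) and it is expected to remain within the scatter. Compound 3 is expected to give 24 h with 11 h to 45 h as the likely range.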

Compound 3, half-life: 52 h
Beside the measured number, compound 3's estimate is 2.2-fold (0.34 log units) below it; measured number outside the range, above it.
By their numbers in this assay, from the lowest: compounds 1, 2 and 3 (each within the scatter of the next).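

For the compounds shown here, this step gives the first one-place comparison for this assay: hydrogen in place of trifluoromethyl on an aromatic carbon, para to a large group, gives a 1.7-fold higher number from compound 1 to compound 3 (0.22 log units; within the scatter) and so shows no resolved change in half-life. At this position, therefore, the half-life of the series does not depend on trifluoromethyl, and the plain phenyl carries the read-out as well as 4-(trifluoromethyl)phenyl within the scatter of repeated measurements. With only this one step, the finding holds for this single exchange on the core of compound 1, and no data shown explain the result.

Still open, as far as these compounds go, is whether any group at this place can move the half-life beyond the scatter, for instance an amine, a carboxylic acid or a longer chain, since trifluoromethyl and hydrogen are the only two substituents compared here. Also open, from the compounds shown here alone, is whether the same exchange would read the same way on another aromatic ring or with the rest of the molecule altered, as a single pair gives no basis for carrying it over.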